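This account rests on a few compounds, and the source may have more. Where it says the series, first, only, none or still open, it means among the compounds named here.

Measured so far:
- compound 1, `O=C(CN(c1nc(Cl)nc2[nH]cnc12)C1CC1)N[C@@H](CO)C(=O)OCc1ccccc1`: 34.2%
- compound 2, `O=C(OCc1ccccc1)[C@@H]1CCCN1C(=O)CN(c1ncnc2c1ncn2C1CCCCO1)C1CC1`: 36.7%
- compound 3, `N=C(N)NCCC[C@H](NC(=O)CN(c1ncnc2c1ncn2C1CCCCO1)C1CC1)C(=O)OCc1ccccc1`: 52.4%

These three compounds were tested in a functional assay on the whole organism (Tail, strain ICR) with Mus musculus as the target, in the tail flick test, with a stated time of 60 min, at a dose of 25 umol/kg by the oral route; a lower number here means a weaker effect, a higher number a stronger effect of the compound at the dose given. Among the three numbers, compound 1 stands lowest. Its nearest neighbour is compound 2, whose number lies within the scatter of repeated measurements, so the two cannot be told apart. Compound 3 lies furthest away, beyond the scatter, so its number is clearly higher than that of compound 1. No pair of these compounds differs in only one place, so no single change can be linked to a step in this assay.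

The unmeasured compound 4, `CSCC[C@H](NC(=O)CN(c1nc(Cl)nc2[nH]cnc12)C1CC1)C(=O)OCc1ccccc1`, differs from compound 1 in one place: (methylsulfanyl)methyl in place of hydroxy on a saturated chain carbon, two bonds along the chain from an amide-type nitrogen and a carbonyl carbon. Going by the values given here, no measured pair shows this change, so there is nothing to set its size against; the expected step in this assay, from compound 1 to compound 4, is a number 3.8 percentage points higher from compound 1 to compound 4 (within the scatter), which is none beyond the scatter. Compound 4 is therefore estimated to give 38% in this assay, with a range from 22% to 55%.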

Compound 4, a percentage reported as activity, at one dose (the size of the read-out at that dose, not a potency): 30.8%
The estimate for compound 4 lay 7.2 percentage points above the measured number, within the range that was stated.
By their numbers in this assay, from the lowest: compounds 4, 1 and 2 (each within the scatter of the next); then compound 3.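

In this assay, going by these compounds alone, putting (methylsulfanyl)methyl in place of hydroxy on a saturated chain carbon, two bonds along the chain from an amide-type nitrogen and a carbonyl carbon, gives a number 3.4 percentage points lower from compound 1 to compound 4 (within the scatter) as the first step that can be read. Compound 1 and compound 4 therefore cannot be told apart at this dose, even though the hydroxy group and its hydrogen-bond donor are gone and a larger, sulfur-bearing group stands in their place. Nothing measured here explains why this exchange leaves the two numbers so close.

As far as these compounds go, what an amine, a carboxylic acid or a plain methyl group on this same chain carbon would do remains open. From the compounds shown here alone, it is also open whether this exchange would give a similar step on a different core.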